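A few compounds are considered here, and "the series" means these few. Any claim that something is new, unique, unknown or untested is made for them only; others in the source may bear on it.

For the measured compounds named here, compound 2 `CCCC(CO)NCc1nc2c(OCC3CCCCC3)cccc2[nH]1` is the only member of the series with a number rather than a limit in an assay on cells for inhibition of interleukin-5 receptor subunit alpha (Mus musculus), read by WST assay, with a stated time of 48 h, in the presence of a further agent that is not named here; on this read-out higher numbers stand for weaker inhibition and lower numbers for stronger inhibition: compound 2 gives 7500 nM. Compound 1 `OCCCCCNCc1nc2c(OCC3CCCCC3)cccc2[nH]1` gives > 30000 nM, which is a limit of this assay, as noted in the limit of > 30000 nM in this assay, at which 1 of the 2 values shown sits. Going by the values given here, the single measured step is an at least 4.0-fold lower number from compound 1 to compound 2 (0.60 log units; beyond the scatter). Compound 3 `COc1ccc(NCc2nc3c(OCC4CCCCC4)cccc3[nH]2)cc1` differs from compound 2 by 4-methoxyphenyl in place of 1-(hydroxymethyl)butyl on an amine nitrogen. Among the compounds with values here, no measured step touches an aromatic substituent on this amine nitrogen, so the change is expected to lie within a 1.3-fold higher number from compound 2 to compound 3 (0.12 log units; within the scatter). Compound 3 is therefore estimated at 10000 nM, in the range 2500 nM to 40000 nM, in this assay.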

Compound 3, half-maximal inhibitory concentration: > 30000 nM
Compound 3 gave a limit, no number; the forecaster's own chance of this, stated with the estimate: 30%; middle value at least 3.0-fold (0.47 log units) away from the limit.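

Placing 4-methoxyphenyl on this amine nitrogen, where compound 2 carries 1-(hydroxymethyl)butyl, gives an at least 4.0-fold higher number from compound 2 to compound 3 (0.60 log units; beyond the scatter) in this assay. So an aromatic substituent at this place, the first one seen, does not keep the measurable inhibition of compound 2. The step between compound 1 and compound 3 cannot be read, and the limit is now shared: the limit of > 30000 nM in this assay, at which 2 of the 3 values shown sit.

The compounds shown leave open whether the loss follows the aromatic ring or the methoxy group, which an unsubstituted phenyl would separate. Also open, going by these compounds, is whether a 1-(hydroxymethyl)propyl or a longer branched chain would give a lower number than compound 2.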